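The source may hold more compounds than are shown below. What is called first, only, known or untested is meant among the compounds shown, and "the series" means these compounds.

Compound 2 `COc1ccc(-c2cc3ccccc3nc2/C=C/C(=O)c2ccc(Br)s2)cc1` carries the shared core with a 5-bromothiophen-2-yl group on the carbonyl carbon. For the measured compounds named here, in a functional assay on H184B5F5/M10 cells (Homo sapiens) for antiproliferative activity, read by XTT assay, with a stated time of 72 h (on this read-out higher numbers stand for weaker inhibition and lower numbers for stronger inhibition), compound 2 gives 9380 nM, which is the only plain number in this small set. Compound 1 `COc1ccc(C(=O)/C=C/c2nc3ccccc3cc2-c2ccc(OC)cc2)cc1` has a 4-methoxyphenyl group in that place instead. In this assay compound 1 gives > 10000 nM, a limit of the assay rather than a number, and it sits at the limit of > 10000 nM in this assay, at which 1 of the 2 values shown sits. Going by the values given here, the single measured step, an at least 1.0-fold lower number from compound 1 to compound 2 (0.02 log units; that floor lies within the scatter), therefore starts from a limit and says only that the two compounds are not far apart. Compound 3 `COc1ccc(-c2cc3ccccc3nc2/C=C/C(=O)c2sccc2N)cc1` differs from compound 2 by 3-aminothiophen-2-yl in place of 5-bromothiophen-2-yl on a carbonyl carbon. Among the compounds with values here, no measured step exchanges bromine for an amino group on the thiophene, so there is nothing to build a direction on. The expected step of a 1.0-fold lower number from compound 2 to compound 3 (0.02 log units; within the scatter) is none beyond the scatter. Compound 3 is estimated at 9000 nM, within 3000 nM to 30000 nM.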

Compound 3, half-maximal inhibitory concentration: > 10000 nM
Compound 3 ended at the assay's limit; the forecaster's own chance of this, stated with the estimate: 45%; middle value at least 1.1-fold (0.04 log units) from the limit.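

In this assay, putting 3-aminothiophen-2-yl on the carbonyl carbon gives an at least 1.0-fold higher number from compound 2 to compound 3 (0.02 log units; that floor lies within the scatter), so a thiophene carrying an amino group stands no clearer of the other compounds than the one carrying bromine. This position has now taken two different thiophenes as well as 4-methoxyphenyl, and none of the three values shown falls far from the top of the measurable range. Compound 3 has a limit rather than a number, and the step from compound 1 to compound 3 cannot be read because both values are limits: the limit of > 10000 nM in this assay, at which 2 of the 3 values shown sit.

As far as these compounds go, how far the true value of compound 3 lies past its limit stays open. So does whether a plain thiophen-2-yl, or a thiophene carrying a carboxylic acid, would give a clearly lower number at this place.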